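The source may report more compounds than this note shows. Statements on the series, on what has been measured and on what is new or still open speak of the compounds shown alone.

Measured so far:
compound 1 `CN(Cc1ccccc1)CC1CCN(CCCc2c[nH]c3ccc(-n4cnnc4)cc23)CC1` — 0.9 nM
compound 2 `CN(CC1CCN(CCCc2c[nH]c3ccc(-n4cnnc4)cc23)CC1)C(=O)Nc1ccccc1` — 5.9 nM

In an assay on CHO cells for displacement of a labelled ligand from 5-hydroxytryptamine receptor 1D (Homo sapiens) (a higher number here means a weaker inhibitor, a lower number a stronger inhibitor), compound 1 holds the lowest of the two numbers. Within the data shown here, the one measured step, a 6.6-fold higher number from compound 1 to compound 2 (0.82 log units; beyond the scatter), puts phenylcarbamoyl in place of benzyl on an amine nitrogen and is modest. Compound 3 `CN(Cc1ccsc1)C1CCN(CCCc2c[nH]c3ccc(-n4cnnc4)cc23)CC1` differs from compound 1 by methyl((thiophen-3-yl)methyl)amino in place of (benzyl(methyl)amino)methyl on a saturated ring carbon. Among the measured compounds shown here, no measured step covers this change, and the step to compound 2 alters a different part of the amine substituent, so it bears only loosely. Compound 3 is expected to stay close to compound 1, with a 1.7-fold higher number from compound 1 to compound 3 (0.22 log units; within the scatter) not beyond the scatter, and its estimate is 1.5 nM within 0.5 nM to 5 nM.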

Compound 3, half-maximal inhibitory concentration: 1.5 nM
Compound 3: middle estimate and measured number agree at the digits printed, within the range that was stated.
By their numbers in this assay, from the lowest: compounds 1 and 3 (each within the scatter of the next); then compound 2.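

In this assay, a 1.7-fold higher number from compound 1 to compound 3 (0.22 log units; within the scatter) shows that methyl((thiophen-3-yl)methyl)amino can stand in place of (benzyl(methyl)amino)methyl on this saturated ring carbon without a change beyond the scatter. The aromatic ring and the link to the saturated ring change together, so this step cannot separate the two. No evidence bears on the reason for this result.

Still open, as far as these compounds go, is how benzyl(methyl)amino on the same ring carbon would compare, which would separate the two changes. Also open, from the compounds shown here alone, is how a pyridine ring in place of the thiophene would read.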